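Working notes: aryl swap at the central ring

The source may report more compounds than this note shows. Statements on the series, on what has been measured and on what is new or still open speak of the compounds shown alone.

Measured so far:
compound 1 `Oc1cccc(-c2cc(-c3cccs3)cc(-c3cccc(O)c3)n2)c1`: 1690 nM
compound 2 `Oc1cccc(-c2cc(-c3ccoc3)cc(-c3ccccc3O)n2)c1`: > 50000 nM
compound 3 `Oc1cccc(-c2cc(-c3ccoc3)cc(-c3cccc(O)c3)n2)c1`: 4630 nM

In a functional assay on HeLa cells (Homo sapiens) for cytotoxicity, read by CCK-8 assay (on this read-out higher numbers stand for weaker inhibition and lower numbers for stronger inhibition), compound 3 gives the highest of the two numbers shown. For compound 2 the assay reports only a limit (the limit of > 50000 nM in this assay, at which 1 of the 3 values shown sits). The nearest number is that of compound 1, and the step of a 2.7-fold higher number from compound 1 to compound 3 (0.44 log units; beyond the scatter) separates the two. The step of an at least 10-fold lower number from compound 2 to compound 3 (1.03 log units; beyond the scatter) concerns the hydroxyphenyl groups and does not bear on the present change.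

Compound 4 `Oc1cccc(-c2cc(-c3cccnc3)cc(-c3cccc(O)c3)n2)c1` differs from compound 3 by pyridin-3-yl in place of furan-3-yl on an aromatic carbon, the group sitting meta to two 3-hydroxyphenyl groups and opposite the ring nitrogen of the shared core. Only the furan-for-thiophene step speaks to a swap at this position, and it was modest. A step of similar size is therefore expected, direction uncertain: a 1.4-fold lower number from compound 3 to compound 4 (0.16 log units; within the scatter). Compound 4 is estimated at 3200 nM, within 1200 nM to 9000 nM.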

Compound 4, half-maximal inhibitory concentration: > 50000 nM
Compound 4 was reported as a limit; the forecaster's own chance of this, stated with the estimate: 10%; at least 15-fold (1.19 log units) between middle value and limit.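

In this assay this position, opposite the ring nitrogen, proves far more sensitive than the furan-for-thiophene swap indicated: an at least 10-fold higher number from compound 3 to compound 4 (1.03 log units; beyond the scatter), and an at least 29-fold higher number from compound 1 to compound 4 (1.47 log units; beyond the scatter). Among the compounds shown, the five-membered rings of compound 1 and compound 3 give measured numbers, while the six-membered pyridin-3-yl of compound 4 does not. The value of compound 4 is a limit: the limit of > 50000 nM in this assay, at which 2 of the 4 values shown sit.

The compounds shown do not separate ring size from the pyridine nitrogen, and phenyl or pyridin-4-yl at this position would address that. From the compounds shown here alone, how a non-aromatic group such as an amine behaves here also stays open.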